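Ether aryl swap: expected clearance of compound 4

This account rests on a few compounds, and the source may have more. Where it says the series, first, only, none or still open, it means among the compounds named here.

In an in vitro ADME assay on microsomes from liver (Homo sapiens) for metabolic stability, tested at 1 uM (on this read-out higher numbers stand for fast clearance and lower numbers for slow clearance), compound 1 `Cn1c(CN2C[C@@H]3C(COc4ccccc4)[C@@H]3C2)nc2ccccc21` gives 14.2 mL/min/kg, the highest of the two numbers reported. Compound 3 `Cn1c(CN2C[C@@H]3C(COc4cccc(-c5ccccc5)c4)[C@@H]3C2)nc2ccccc21` gives 11 mL/min/kg in this assay, and the step of a 1.3-fold lower number from compound 1 to compound 3 (0.11 log units; within the scatter) shows that this change did not move the number. Compound 2 `c1ccc(OCC2[C@H]3CN(Cc4nc5ccccc5s4)C[C@@H]23)cc1` reaches only the limit of this assay, < 5.3 mL/min/kg. Compound 4 `Cn1c(CN2C[C@@H]3C(COc4ccc(Cl)cn4)[C@@H]3C2)nc2ccccc21` differs from compound 1 by 5-chloropyridin-2-yl in place of phenyl on an oxygen on a saturated carbon. Within the data shown here, no measured step covers this exchange at the ether; the one step available, from compound 1 to compound 3, stayed within the scatter, so no step beyond the scatter is expected here, with the lower end open toward the limit (the limit of < 5.3 mL/min/kg in this assay, at which 1 of the 3 values shown sits). The expected step of a 1.4-fold lower number from compound 1 to compound 4 (0.15 log units; within the scatter) is therefore small. Compound 4 is estimated at 10 mL/min/kg, between 5.3 mL/min/kg and 20 mL/min/kg.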

Compound 4, clearance: 12.3 mL/min/kg
Estimate against measurement, compound 4: 1.2-fold (0.09 log units) below; measured number inside the range.
By their numbers in this assay, from the lowest: compounds 3, 4 and 1 (each within the scatter of the next). At a limit, below all of these: compound 2.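

Replacing phenyl on the oxygen with 5-chloropyridin-2-yl gives a 1.2-fold lower number from compound 1 to compound 4 (0.06 log units; within the scatter) in this assay, so exchanging the whole aryl group leaves the number as unmoved as adding phenyl to it did. A ring with a hetero atom and a chlorine therefore fits at this position with clearance unchanged. No measured evidence shown bears on a cause for this step.

Going by these compounds, whether any group on this oxygen moves clearance beyond the scatter remains open. A saturated chain in place of the aryl ring, or an amine or carboxylic acid on it, would test this.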